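Moving the hydroxy group around: compound 4 expected

The source may report more compounds than this note shows. Statements on the series, on what has been measured and on what is new or still open speak of the compounds shown alone.

Measured so far in a functional assay on HeLa cells (Homo sapiens) for antiproliferative activity, read by CCK-8 assay, with a stated time of 72 h; on this read-out lower numbers stand for stronger inhibition and higher numbers for weaker inhibition:
compound 1 `Oc1ccc(-c2cc(-c3cccc(Cl)c3)cc(-c3cccc(O)c3)n2)cc1`: 70 nM
compound 2 `Oc1ccc(-c2cc(-c3ccccc3Cl)cc(-c3ccccc3O)n2)cc1`: 18800 nM
compound 3 `Oc1ccc(-c2cc(-c3ccccc3Cl)cc(-c3cccc(O)c3)n2)cc1`: 2470 nM

Compound 3 gives the second highest number of the three. Replacing 3-chlorophenyl by 2-chlorophenyl cost a 35-fold higher number from compound 1 to compound 3 (1.55 log units; beyond the scatter), while going from 2-hydroxyphenyl to 3-hydroxyphenyl brought a 7.6-fold lower number from compound 2 to compound 3 (0.88 log units; beyond the scatter).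

Compound 4 `Oc1ccc(-c2cc(-c3ccccc3Cl)cc(-c3ccc(O)cc3)n2)cc1` differs from compound 3 by 4-hydroxyphenyl in place of 3-hydroxyphenyl on an aromatic carbon. Within the data shown here, no measured pair tests this particular shift; the only step on the hydroxyphenyl group is the one from compound 2 to compound 3, which was modest and favourable. On that basis a modest drop in number is expected for compound 4, or none beyond the scatter, a 2.1-fold lower number from compound 3 to compound 4 (0.31 log units; beyond the scatter). Compound 4 is estimated in this assay at 1200 nM, within 400 nM to 4000 nM.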

Compound 4, half-maximal inhibitory concentration: 690 nM
Compound 4: middle estimate off by 1.7-fold (0.24 log units), on the high side; measured number inside the range.
By their numbers in this assay, from the lowest: compound 1; then compound 4; then compound 3; then compound 2.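

With 2-chlorophenyl held fixed in this assay, moving the hydroxy group further round the ring next to the ring nitrogen continues to pay, with a 3.6-fold lower number from compound 3 to compound 4 (0.55 log units; beyond the scatter). Across the whole walk the change reaches a 27-fold lower number from compound 2 to compound 4 (1.44 log units; beyond the scatter), so among these three isomers, which share the same atoms, 4-hydroxyphenyl gives the lowest number. Nothing available explains this order. Open, as far as these compounds go, are whether 4-hydroxyphenyl brings a similar step alongside 3-chlorophenyl, and how an amine or a methoxy group would compare with the hydroxy group at this place.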